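The source may report more compounds than this note shows. Statements on the series, on what has been measured and on what is new or still open speak of the compounds shown alone.

The set here consists of three cyanoacrylamide and cyanoacrylketone compounds. Among the measured compounds shown here, compound 1 `N#C/C(=C\c1ccc(Cl)cc1)C(=O)c1ccc[nH]1` is the only member with a numerical reading: in a functional assay on MIA cells (Homo sapiens) for inhibition, read by MTT assay, with a stated time of 72 h (a higher number here means a weaker inhibitor of growth, a lower number a stronger inhibitor of growth), compound 1 gives 48000 nM. Compound 2 `COc1ccc(CNC(=O)/C(C#N)=C/c2ccc[nH]2)cc1` is the amide analogue with the aromatic ring on the other side of the chain. For compound 2 in this assay only a limit is reported, > 50000 nM, so compound 2 stands at the boundary of what the measurement records (the limit of > 50000 nM in this assay, at which 1 of the 2 values shown sits). Compound 3 `COc1ccc(CNC(=O)/C(C#N)=C/c2ccc(C)cc2)cc1` has not been measured and differs from compound 2 by 4-methylphenyl in place of 1H-pyrrol-2-yl on a double-bonded chain carbon bound to a double-bonded chain carbon. For the measured compounds named here, no step between measured compounds exists to gauge what this change does, and compound 1, with 48000 nM, shows only that the series as a whole is weak. Compound 3 is therefore expected to remain weak, with an estimated step of an at least 1.2-fold lower number from compound 2 to compound 3 (0.09 log units; that floor lies within the scatter) that may amount to no more than scatter. Compound 3 in this assay is expected to give about 40000 nM, within a range from 10000 nM to 120000 nM.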

Compound 3, concentration for 50% growth inhibition: 38000 nM
Compound 3: middle estimate off by 1.1-fold (0.02 log units), on the high side; measured number inside the range.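

In this assay, the replacement of 1H-pyrrol-2-yl by 4-methylphenyl on a double-bonded chain carbon bound to a double-bonded chain carbon now has a first reading: an at least 1.3-fold lower number from compound 2 to compound 3 (0.11 log units; that floor lies within the scatter). The change gives a numerical value for compound 3 where compound 2 has none, but the printed floor does not establish a change beyond the scatter. The step can be read only as a floor because compound 2 has a limit and not a number: the limit of > 50000 nM in this assay, at which 1 of the 3 values shown sits.

From the compounds shown here alone, how large the true step is remains open, as does whether the hydrogen-bond donor that leaves with the 1H-pyrrol-2-yl plays any part in it. Going by these compounds, it is also open whether a group carrying an amine or a carboxylic acid in this place would give a clearly lower number than compound 3 in this assay.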